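A few compounds are considered here, and "the series" means these few. Any claim that something is new, unique, unknown or untested is made for them only; others in the source may bear on it.

Measured in a functional assay on T47D cells (Homo sapiens) for inhibition, read by CCK-8 assay, with a stated time of 72 h, tested at 10 uM; a lower number here means less inhibition of growth, a higher number more inhibition of growth at the concentration tested:
- compound 1 `CN(C)C(=O)c1cc2cnc(Nc3ccc(NC(=O)C4(C(=O)Nc5cccc(Cl)c5)CC4)cc3)nc2n1C1CCCC1`: 92.6%
- compound 2 `CN(C)C(=O)c1cc2cnc(Nc3ccc(NC(=O)C4(C(=O)Nc5ccc(F)cc5)CC4)cc3F)nc2n1C1CCCC1`: 67.9%

Compound 1 holds the higher of these two numbers, and compound 2 lies lower by a gap beyond the usual scatter of such measurements. The two compounds differ in more than one place, so their gap cannot be tied to any single change.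

The next compound is compound 3 `CN(C)C(=O)c1cc2cnc(Nc3ccc(NC(=O)C4(C(=O)Nc5ccc(O)cc5)CC4)cc3)nc2n1C1CCCC1`. It keeps the shared core of compound 1 and changes one group, with 4-hydroxyphenyl in place of 3-chlorophenyl on an amide-type nitrogen. Among the measured compounds shown here, no measured pair tests this swap directly, so the expectation is a rough one.

Compound 1, at 92.6%, leaves little room for a rise. A related structure can also read much lower, as compound 2 does at 67.9%. A fall beyond the scatter is therefore expected in this assay, with an estimated size of a number 26.6 percentage points lower from compound 1 to compound 3 (beyond the scatter).

Compound 3 is estimated at 66%, with an expected range of 42% to 88%.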

Compound 3, percent growth inhibition at one concentration: 95.8%
Beside the measured number, compound 3's estimate is 29.8 percentage points below it; the whole stated range lies below it.
By their numbers in this assay, from the lowest: compound 2; then compounds 1 and 3 (each within the scatter of the next).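

In this assay, putting 4-hydroxyphenyl in place of 3-chlorophenyl on the amide-type nitrogen gives a number 3.2 percentage points higher from compound 1 to compound 3 (within the scatter). Among the compounds shown here, this is the first direct test of this position, and it shows that the aromatic group there can be exchanged without a change in growth inhibition beyond the scatter, even though the incoming group brings a hydrogen-bond donor and a hydrogen-bond acceptor that the outgoing group lacks. Nothing available here explains why the two groups read alike.

This single swap replaces the chlorine with a hydroxyl and also moves the substituent to a different place on the ring, so the two changes cannot be told apart, and a reading taken at one concentration may hide differences in strength between such active compounds. As far as these compounds go, it also remains open how far this tolerance extends, for instance whether an amine or a carboxylic acid on the phenyl ring, or a saturated cyclohexyl ring in place of the phenyl ring, would read the same way.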